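Moving a bromine around the phenyl on the tetrazole nitrogen

The source may report more compounds than this note shows. Statements on the series, on what has been measured and on what is new or still open speak of the compounds shown alone.

The measured compounds:
compound 1, `COc1ccc(Nc2nnnn2-c2cccc(Br)c2)cc1`, 107000 nM
compound 2, `COc1ccc(-n2nnnc2Nc2ccccc2Br)cc1`, 137000 nM
compound 3, `COc1ccc(Nc2nnnn2-c2ccc(Cl)cc2)cc1`, 102000 nM

All three were tested in an ADME assay on HaCaT cells (Homo sapiens) for cytotoxicity, read by MTT assay, with a stated time of 72 h; on this read-out higher numbers stand for weaker inhibition and lower numbers for stronger inhibition. Compound 2 gives the top number of the three, yet its gaps to compound 1 and to compound 3 both lie within the usual scatter, so the three compounds cannot be separated on these numbers. Among the compounds with values here, the one step between measured compounds, a 1.0-fold lower number from compound 1 to compound 3 (0.02 log units; within the scatter), swaps one halogenated phenyl for another on an aromatic nitrogen and leaves the read-out unchanged beyond the scatter.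

Compound 4, `COc1ccc(-n2nnnc2Nc2cccc(Br)c2)cc1`, has not yet been measured in this assay. It differs from compound 2 as follows: 3-bromophenyl in place of 2-bromophenyl on a nitrogen on an aromatic ring. This is again a rearrangement of a halogenated phenyl with no change in atom count. Within the data shown here, the only step that bears on it, a 1.0-fold lower number from compound 1 to compound 3 (0.02 log units; within the scatter), was flat, so no movement beyond the scatter is expected in this assay. Compound 4 is therefore expected to give about 120000 nM, within 70000 nM to 200000 nM, meaning an expected step of a 1.1-fold lower number from compound 2 to compound 4 (0.06 log units; within the scatter).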

Compound 4, half-maximal inhibitory concentration: 138000 nM
For compound 4 the middle estimate is 1.2-fold (0.06 log units) below the measured one; the measured number falls inside the stated range.
By their numbers in this assay, from the lowest: compounds 3, 1, 2 and 4 (each within the scatter of the next).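

Within the data shown here, the step of a 1.0-fold higher number from compound 2 to compound 4 (0.00 log units; within the scatter) is the first to test the bromine alone, since 3-bromophenyl in place of 2-bromophenyl keeps the same atoms and the same place on a nitrogen on an aromatic ring. The earlier step changed both the halogen and its place on the phenyl, so it could not isolate this move, whereas here the swap of 2-bromophenyl for 3-bromophenyl leaves the number in this assay within the scatter. Both steps read so far are therefore flat, with none among these compounds going against that, and no supporting data bear on this result.

The compounds shown leave open whether an amine or a carboxylic acid in place of the bromine would move the number beyond the scatter. They also leave open whether 4-bromophenyl at this same place would behave like 2-bromophenyl and 3-bromophenyl.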